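An Ester Replaces the Fluorophenyl Arm of Compound 3

This account rests on a few compounds, and the source may have more. Where it says the series, first, only, none or still open, it means among the compounds named here.

Compound 1 `O=C1C(Nc2ccc(CO)cc2)=CC(=O)c2ncncc21`: 5700 nM
Compound 2 `COc1ccc(NC2=CC(=O)c3ncncc3C2=O)cc1`: 1700 nM
Compound 3 `O=C1C(Nc2ccc(-c3ccc(F)cc3)cc2)=CC(=O)c2ncncc21`: 4400 nM

These three analogues share one core and were tested in a functional assay on BXPC-3 cells (Homo sapiens) for cytotoxicity, read by MTT assay, with a stated time of 72 h; a higher number here means a weaker inhibitor, a lower number a stronger inhibitor. Compound 3 stands second highest of the three numbers: its nearest neighbour is compound 1, as a 1.3-fold lower number from compound 1 to compound 3 (0.11 log units; within the scatter), while the gap to compound 2 is larger, as a 2.6-fold higher number from compound 2 to compound 3 (0.41 log units; beyond the scatter). Compound 4 `CCOC(=O)c1ccc(NC2=CC(=O)c3ncncc3C2=O)cc1` differs from compound 3 in one place: ethoxycarbonyl in place of 4-fluorophenyl on an aromatic carbon. Going by the values given here, no measured step involves an ethoxycarbonyl group. The two steps that alter the same position, a 1.3-fold lower number from compound 1 to compound 3 (0.11 log units; within the scatter) and a 2.6-fold higher number from compound 2 to compound 3 (0.41 log units; beyond the scatter), were small to modest and ran in opposite directions, so for compound 4 in this assay only a small step is expected, with no firm direction. Compound 4 is estimated at 4000 nM, within 1500 nM to 11000 nM, meaning an expected step of a 1.1-fold lower number from compound 3 to compound 4 (0.04 log units; within the scatter).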

Compound 4, half-maximal inhibitory concentration: 5900 nM
Compound 4: middle estimate off by 1.5-fold (0.17 log units), on the low side; measured number inside the range.
By their numbers in this assay, from the lowest: compound 2; then compounds 3, 1 and 4 (each within the scatter of the next).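

In (this assay), replacing 4-fluorophenyl with ethoxycarbonyl, which has no ring and two hydrogen-bond acceptors, stays within the scatter (a 1.3-fold higher number from compound 3 to compound 4 (0.13 log units; within the scatter)), and the same holds for ethoxycarbonyl against hydroxymethyl (a 1.0-fold higher number from compound 1 to compound 4 (0.01 log units; within the scatter)). Methoxy alone stands apart at this position (a 3.5-fold higher number from compound 2 to compound 4 (0.54 log units; beyond the scatter)), which makes compound 2 the strongest of the four, with its steps to all three others beyond the scatter. Nothing shown here explains why methoxy differs from the other three groups. The compounds shown leave open whether a carboxylic acid, an amine or a longer ether chain at this position would match methoxy or join the other three groups.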